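The source may report more compounds than this note shows. Statements on the series, on what has been measured and on what is new or still open speak of the compounds shown alone.

Working notes on the series. The shared core carries an ester at each of two oxygens on saturated carbons. Among the compounds with values here, compound 3 `COc1ccccc1C(=O)O[C@@H]1CO[C@H]2[C@@H]1OC[C@@H]2OC(=O)c1ccccc1OC(C)=O` in an ADME assay on a cell-free system (plasma, Homo sapiens) for metabolic stability, with Plasma (Rattus norvegicus) as the target, read by HPLC, at pH 7.4 (a lower number here means that the compound disappears faster, a higher number that the compound lasts longer), gives 0.0578 h; it stands second highest of the three numbers so far, with compound 2 nearest and compound 1 furthest, both within the scatter. Compound 1 `CC(=O)Oc1ccccc1C(=O)O[C@H]1CO[C@H]2[C@@H]1OC[C@H]2OC(=O)c1snnc1C` gives 0.0642 h and compound 2 `CC(=O)Oc1ccccc1C(=O)O[C@H]1CO[C@H]2[C@@H]1OC[C@H]2O` gives 0.055 h in this assay. The steps seen so far are a 1.2-fold lower number from compound 1 to compound 2 (0.07 log units; within the scatter), a 1.1-fold lower number from compound 1 to compound 3 (0.05 log units; within the scatter) and a 1.1-fold higher number from compound 2 to compound 3 (0.02 log units; within the scatter).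

Compound 4 `CC(=O)Oc1ccccc1C(=O)O[C@H]1CO[C@H]2[C@@H]1OC[C@H]2OC(=O)CO[N+](=O)[O-]` differs from compound 3 by (nitrooxy)methyl in place of 2-methoxyphenyl on a carbonyl carbon. The step bearing most directly on this change is a 1.1-fold lower number from compound 1 to compound 3 (0.05 log units; within the scatter), which swaps the group on the same carbonyl carbon; a 1.2-fold lower number from compound 1 to compound 2 (0.07 log units; within the scatter), removing that acyl group altogether, is also within the scatter. Three different substituents at that position gave numbers within the scatter of one another, so no step beyond the scatter is expected here: a 1.0-fold higher number from compound 3 to compound 4 (0.00 log units; within the scatter) is the expected step. Compound 4 is therefore estimated at 0.058 h, with a range of 0.03 h to 0.12 h.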

Compound 4, half-life: 0.06 h
Estimate against measurement, compound 4: 1.0-fold (0.01 log units) below, and the stated range covers the measured number.
By their numbers in this assay, from the lowest: compounds 2, 3, 4 and 1 (each within the scatter of the next).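

In this assay the position now also holds an open chain with no ring: a 1.0-fold higher number from compound 3 to compound 4 (0.02 log units; within the scatter) and a 1.1-fold lower number from compound 1 to compound 4 (0.03 log units; within the scatter), so (nitrooxy)methyl on this carbonyl carbon reads the same as either aromatic group. Against the free hydroxyl compound, the result is a 1.1-fold higher number from compound 2 to compound 4 (0.04 log units; within the scatter), so ((nitrooxy)methyl)carbonyl in place of hydrogen does not separate the numbers either, and all four compounds remain together whether this oxygen is acylated or not. No measurement at hand bears on what sets these short half-lives.

Going by these compounds, whether an amine or a carboxylic acid on the acyl group at this position, or a longer chain in place of (nitrooxy)methyl, would give a step beyond the scatter remains open. Also open, on these data alone, is what an amide in place of the ester at this oxygen would give.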